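A few compounds are considered here, and "the series" means these few. Any claim that something is new, unique, unknown or untested is made for them only; others in the source may bear on it.

Measured compounds in an assay on isolated protein for inhibition of protein kinase C zeta type (Homo sapiens), with a stated time of 4 min; a lower number here means a stronger inhibitor, a higher number a weaker inhibitor:
- compound 1 `CC(C)(C)C1=NN(c2ccc(F)cc2)C(c2ccc(O)cc2)C1`: 9400 nM
- compound 2 `CC(C)(C)C1=NN(c2ccccc2Cl)C(c2ccc(O)cc2)C1`: "not determined" (no result reported)
- compound 3 `CC(C)(C)C1=NN(c2ccc(F)cc2F)C(c2ccc(O)cc2)C1`: "not determined" (no result reported)

Compound 3 thus stands without a single number in this assay, and compound 2 is a further entry without one; only compound 1 offers a figure, and it marks a weak inhibitor. The step to compound 4 `CC(C)(C)C1=NN(c2ccc(F)c(Cl)c2)C(c2ccc(O)cc2)C1` brings (3-chloro-4-fluorophenyl in place of 2,4-difluorophenyl on an amine nitrogen in a ring). Going by the values given here, no step between two measured compounds is available to guide the size of this change, so the expectation is a shift no larger than the usual scatter, in no firm direction, anchored on compound 1. On that basis compound 4 is estimated at 9000 nM in this assay, within a range from 2500 nM to 35000 nM.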

Compound 4, half-maximal inhibitory concentration: 900 nM
For compound 4 the middle estimate is 10-fold (1.00 log units) above the measured one; measured number outside the range, below it.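

In this assay, a single chloro in place of hydrogen on the aromatic ring, turning the 4-fluorophenyl group into 3-chloro-4-fluorophenyl, gives a 10-fold lower number from compound 1 to compound 4 (1.02 log units; beyond the scatter), so this aryl group on the ring nitrogen responds strongly to a small change. The comparison with compound 3 cannot be read, since compound 3 has no number. Nothing available explains why the chloro has this effect. The compounds shown leave open whether a bromo, a methyl or an amine in that place would match the chloro, and whether the fluoro is needed alongside it.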